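A few compounds are considered here, and "the series" means these few. Any claim that something is new, unique, unknown or untested is made for them only; others in the source may bear on it.

Measured so far in a functional assay on KG-1 cells (Homo sapiens) for cytotoxicity, read by luminescence and CellTiter-Glo, with a stated time of 3 days (a lower number here means a stronger inhibitor, a higher number a weaker inhibitor), for the series:
compound 1 `N#Cc1ccc(NC(=O)c2cc(F)ccc2O)cc1` gives 2670 nM
compound 2 `O=C(Nc1ccc(C(F)(F)F)cc1)c1cc(F)ccc1O` gives 1700 nM
compound 3 `O=C(Nc1ccc([N+](=O)[O-])cc1)c1cc(F)ccc1O` gives 1100 nM

Compound 2 holds the middle number of the three, yet a 1.6-fold lower number from compound 1 to compound 2 (0.20 log units; within the scatter) and a 1.5-fold lower number from compound 2 to compound 3 (0.19 log units; within the scatter) leave it unseparated from either neighbour.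

Compound 4 `O=C(Nc1ccc(C(F)(F)F)cc1)c1cc(Br)ccc1O` carries bromo in place of fluoro on an aromatic carbon, para to a hydroxy group. The count of that change against compound 2 reads bromo in place of fluoro on an aromatic carbon with nothing else altered in the structure.

Within the data shown here, no measured step touches this place. All three exchange cyano, trifluoromethyl or nitro at a different place while fluoro stays, so they serve only as a gauge of how far the numbers move in this series. The largest, a 2.4-fold lower number from compound 1 to compound 3 (0.39 log units; beyond the scatter) is the only one beyond the scatter, and it is modest. As far as these compounds go, the data hold no exchange of fluoro for bromo, so the direction stays open. A small step with a slight lean to a lower number is expected, and none beyond the scatter. The expected move is a 1.7-fold lower number from compound 2 to compound 4 (0.23 log units; within the scatter) as a working estimate. For compound 4 the estimate is 1000 nM with an expected range from 350 nM to 2900 nM in these notes.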

Compound 4, half-maximal inhibitory concentration: 610 nM
The estimate for compound 4 lay 1.6-fold (0.21 log units) above the measured number; the measured number falls inside the stated range.
By their numbers in this assay, from the lowest: compounds 4, 3, 2 and 1 (each within the scatter of the next, the first and the last beyond it).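

In this assay, the place para to a hydroxy group proves responsive: with bromo in place of fluoro and nothing else altered, the step is a 2.8-fold lower number from compound 2 to compound 4 (0.45 log units; beyond the scatter), modest but beyond the scatter. The earlier steps shown here held fluoro fixed and exchanged cyano, trifluoromethyl or nitro at a different place, so they gave no reading here; only a 2.4-fold lower number from compound 1 to compound 3 (0.39 log units; beyond the scatter) among them passed the scatter, and this exchange now shows that the series can also be moved from the hydroxy-bearing side of the core. No measurement shown here bears on why the number moves with this exchange.

As far as these compounds go, the step rests on a single pair, with trifluoromethyl held constant, so it remains open whether bromo in place of fluoro gives a similar step with cyano or nitro in that other place. Also open, from the compounds shown here alone, is how this place responds to other groups, such as chloro, iodo, methyl, methoxy or an amine, and whether the lower number seen with bromo extends to any of them.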